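An Iodo Compound Without a Drawn Double-Bond Configuration

The compounds below may be only part of what the source reports. "The series", "measured", "known", "first", "only" and "open" are said of these compounds alone.

In a functional assay on U-87MG ATCC cells (Homo sapiens) for cytotoxicity, read by MTT assay, with a stated time of 48 h (on this read-out higher numbers stand for weaker inhibition and lower numbers for stronger inhibition), compound 1 `C/C(=N\NC(=S)Nc1ccc(I)cc1)c1ccccn1` gives 59 nM. Compound 2 `C/C(=N\NC(=S)Nc1ccc(F)cc1)c1ccccn1` gives 10 nM, which leaves compound 1 with the higher of the two numbers. Among the measured compounds shown here, the only measured step is a 5.9-fold lower number from compound 1 to compound 2 (0.77 log units; beyond the scatter), and it places fluoro in place of iodo on an aromatic carbon.

Compound 3 `CC(=NNC(=S)Nc1ccc(I)cc1)c1ccccn1` has not yet been measured in this assay. Its relation to compound 1 is this: the two compounds have the same atoms and bonds; at least one stereo element is drawn with a configuration in one of them and without one in the other: 1 of 1 stereo elements differ; a double bond is drawn E in compound 1 and without a configuration in compound 3. The two compounds have the same atoms and bonds, so compound 3 keeps the iodo group, and the only difference lies in how the double bond is drawn.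

The measured step therefore bears on this comparison only indirectly, since it concerns a change of group rather than a drawn configuration. For the measured compounds named here, no measured pair differs in the way compound 1 and compound 3 do. With no change of atoms or bonds, no shift beyond the scatter is expected, and the estimated result is no change at the digits printed from compound 1 to compound 3 (within the scatter). Compound 3 is expected at 59 nM, within an estimated range of 28 nM to 125 nM.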

Compound 3, half-maximal inhibitory concentration: 59 nM
Compound 3: middle estimate and measured number agree at the digits printed; low and high end bracket the measured number.
By their numbers in this assay, from the lowest: compound 2; then compounds 1 and 3 (each within the scatter of the next).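

In this assay, the way the double bond is drawn makes no visible difference for the iodo compounds: the step reads no change at the digits printed from compound 1 to compound 3 (within the scatter). The earlier pair had shown only that the number responds to a change of group on an aromatic carbon, as a 5.9-fold lower number from compound 1 to compound 2 (0.77 log units; beyond the scatter), whereas this pair shows that a difference at the double bond, with the iodo group kept, leaves the number where it stood. The two compounds are separated by a matter of depiction alone, with no atom or bond changed: the fact that one of compounds 1 and 3 is drawn with a defined configuration and the other without, at the place where they differ

These numbers cannot tell whether the material behind compound 3 holds a single form of the double bond or a mixture of forms, and the compounds shown include none drawn with the opposite configuration at that bond. Also open, on these data alone, is what a chloro, bromo or methoxy group would give on the aromatic carbon that carries iodo in compound 1 and fluoro in compound 2, and whether compound 2 would keep its number if its double bond were drawn without a configuration.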